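Iodo for thiophen-3-yl on the core of compound 1

A few compounds are considered here, and "the series" means these few. Any claim that something is new, unique, unknown or untested is made for them only; others in the source may bear on it.

Compound 1 `CNc1ncnc2c1c(-c1ccsc1)cn2[C@@H]1O[C@H](CO)[C@@H](O)[C@H]1O` is read in a functional assay on HCT-116 cells (Homo sapiens), read by MTT assay, with a stated time of 72 h (on this read-out higher numbers stand for weaker inhibition and lower numbers for stronger inhibition), only as a limit, > 20000 nM, and so sits at the weakest end of the values shown (the limit of > 20000 nM in this assay, at which 1 of the 3 values shown sits). Compound 2 `COc1ncnc2c1c(-c1ccsc1)cn2[C@@H]1O[C@H](CO)[C@@H](O)[C@H]1O` gives 120 nM and compound 3 `Cc1ncnc2c1c(-c1ccsc1)cn2[C@@H]1O[C@H](CO)[C@@H](O)[C@H]1O` gives 460 nM; the two changes at the methylamino carbon, an at least 160-fold lower number from compound 1 to compound 2 (2.22 log units; beyond the scatter) and an at least 43-fold lower number from compound 1 to compound 3 (1.63 log units; beyond the scatter), are both large, while the step of a 3.8-fold higher number from compound 2 to compound 3 (0.58 log units; beyond the scatter) is modest. Compound 4 `CNc1ncnc2c1c(I)cn2[C@@H]1O[C@H](CO)[C@@H](O)[C@H]1O` keeps the methylamino group of compound 1 and differs from it only by iodo in place of thiophen-3-yl on an aromatic carbon. Going by the values given here, none of the measured steps touches this position, so no measured step bears directly on the change, and the series holds no value for any iodo analogue. Compound 1 stands only at a limit. The step expected is a number no higher from compound 1 to compound 4 (the limit leaves the size open), that is, no shift beyond the scatter that can be placed in either direction. The estimate for compound 4 in this assay is 20000 nM, within 4000 nM to 100000 nM, with a considerable chance that again only a limit is returned.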

Compound 4, half-maximal inhibitory concentration: > 100000 nM
Compound 4: no number, only a limit; the forecaster's own chance of this, stated with the estimate: 70%; middle value at least 5.0-fold (0.69 log units) away from the limit.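

In this assay, compound 1 and compound 4 both return only limits, so the step from thiophen-3-yl to iodo cannot be read. The compounds shown leave open what iodo in place of thiophen-3-yl does when methoxy or methyl replaces methylamino.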